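Replacing a Furan Ring with Phenyl: An Expected Step

A few compounds are considered here, and "the series" means these few. Any claim that something is new, unique, unknown or untested is made for them only; others in the source may bear on it.

Of the compounds shown here, three sharing one core have been tested in an assay on isolated protein for inhibition of DNA topoisomerase 1 (Homo sapiens), with a stated time of 30 min, tested at 100 uM; on this read-out higher numbers stand for a stronger effect at the one concentration tested and lower numbers for a weaker effect. Compound 1 `Oc1ccc(-c2cc(-c3ccccc3)nc(-c3ccccc3Cl)c2)cc1` gives 13.6%. Compound 2 `Oc1ccc(-c2cc(-c3ccc(Cl)cc3)nc(-c3cccs3)c2)cc1` gives 38.8%, the highest of the three numbers. Compound 3 `Oc1ccc(-c2cc(-c3ccc(Cl)cc3)nc(-c3ccco3)c2)cc1` gives 15.8%, the second highest of the three; it sits within the scatter of compound 1 and beyond the scatter below compound 2. Going by the values given here, the only measured step between neighbouring structures, a number 23 percentage points lower from compound 2 to compound 3 (beyond the scatter), shows that exchanging one five-membered ring for another at the position next to the ring nitrogen moves the number by a modest but real amount.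

Compound 4 `Oc1ccc(-c2cc(-c3ccccc3)nc(-c3ccc(Cl)cc3)c2)cc1` has not yet been measured. Compared with compound 3 it shows (phenyl in place of furan-2-yl on an aromatic carbon). Among the compounds with values here, no measured step exchanges a five-membered ring for a phenyl at this position, so the step from compound 2 to compound 3 is only a loose guide: it suggests that a change at this position can shift the read-out modestly, without telling in which direction a phenyl would move it. On that basis compound 4 is expected to give about 20%, with a likely range from 5% to 45%. This estimate means an expected step of a number 4.2 percentage points higher from compound 3 to compound 4 (within the scatter), which is expected to stay within the scatter.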

Compound 4, a percentage reported as inhibition, at one concentration (the size of the read-out at that concentration, not a potency): 68%
Compound 4: middle estimate off by 48 percentage points, on the low side; the measured number lies above the stated range.
By their numbers in this assay, from the lowest: compounds 1 and 3 (each within the scatter of the next); then compound 2; then compound 4.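

In this assay, a six-membered phenyl ring next to the ring nitrogen gives a far higher number than either five-membered ring: the furan-2-yl swap gives a number 52.2 percentage points higher from compound 3 to compound 4 (beyond the scatter), and the thiophen-2-yl swap gives a number 29.2 percentage points higher from compound 2 to compound 4 (beyond the scatter). These steps show that this position can carry much more of the read-out than the exchange between the two five-membered rings had revealed, and that, with a 4-chlorophenyl group in the molecule, phenyl ranks above both of them here. The place of a single chlorine also matters, since 4-chlorophenyl in place of 2-chlorophenyl gives a number 54.4 percentage points higher from compound 1 to compound 4 (beyond the scatter), although no available measurement explains any of these jumps.

As far as these compounds go, what remains open is whether the phenyl ring can be improved further, for example by placing an amine or a carboxylic acid on it, or whether a saturated ring such as piperidine would hold the number at this position. These are single-concentration read-outs, so the compounds shown also leave open how potent compound 4 is.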